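The compounds below may be only part of what the source reports. "The series", "measured", "known", "first", "only" and "open" are said of these compounds alone.

Measured compounds:
compound 1 `N#C[C@@]1(NC(=O)[C@@H](CC(=O)N2CCOCC2)CC2CCC(c3ccccc3)CC2)CCN(C2CCCCC2)C1`: 3140 nM
compound 2 `N#CC1(NC(=O)[C@@H](CC(=O)N2CCOCC2)CC2CCCCC2)CC1`: 135 nM
compound 3 `N#C[C@@]1(NC(=O)[C@@H](CC(=O)N2CCOCC2)CC2CCc3ccccc3C2)CCN(C2CCCCC2)C1`: 1.9 nM

In an assay on isolated protein for inhibition of cathepsin S (Homo sapiens) (on this read-out higher numbers stand for weaker inhibition and lower numbers for stronger inhibition), compound 2 sits second highest of the three numbers. Compound 1 is its nearest neighbour, with a higher number, while compound 3 gives the lowest number of the set. For the measured compounds named here, compound 2 differs from each of those two in more than one place, so no single step connects them and only the bare values can be compared.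

Compound 4 `CN1CCC(C#N)(NC(=O)[C@@H](CC(=O)N2CCOCC2)CC2CCCCC2)CC1` is not yet measured. It arises from compound 2 by one change: 4-cyano-1-methylpiperidin-4-yl in place of 1-cyanocyclopropyl on an amide-type nitrogen. Going by the values given here, the only step measured so far, a 1700-fold lower number from compound 1 to compound 3 (3.22 log units; beyond the scatter), concerns a group on the saturated chain carbon and not the amide-type nitrogen, so it does not bear on this change. Among the compounds with values here, there is therefore no measured step that speaks directly to the step from compound 2 to compound 4. In the absence of such evidence, a number close to that of compound 2 is expected, with a modest lean toward a lower number, meaning a 1.5-fold lower number from compound 2 to compound 4 (0.18 log units; within the scatter). Compound 4 is estimated at 90 nM, within a range of 20 nM to 400 nM.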

Compound 4, half-maximal inhibitory concentration: 251 nM
Beside the measured number, compound 4's estimate is 2.8-fold (0.45 log units) below it; low and high end bracket the measured number.
By their numbers in this assay, from the lowest: compound 3; then compounds 2 and 4 (each within the scatter of the next); then compound 1.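

In this assay, the amide-type nitrogen accepts 4-cyano-1-methylpiperidin-4-yl in place of 1-cyanocyclopropyl with a 1.9-fold higher number from compound 2 to compound 4 (0.27 log units; within the scatter), so the two compounds cannot be told apart on this read-out. For the compounds shown here, this is the first measured change at this place, and it shows that a six-membered ring with 1 hetero atom and 9 heavy atoms can stand where a three-membered carbon ring with 5 heavy atoms stood without a change beyond the scatter. No available evidence explains why the two groups read alike.

Going by these compounds, whether the nitrogen in the new ring or its methyl group matters at all remains open. A 4-cyanotetrahydropyran-4-yl group, with an oxygen in that ring, or a 4-cyanopiperidin-4-yl group with an acetyl on the ring nitrogen, would begin to separate those two questions.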